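Lengthening the Side Chain on the Core of Compound 3

The source may report more compounds than this note shows. Statements on the series, on what has been measured and on what is new or still open speak of the compounds shown alone.

Compound 1 `CC[C@@H]1C(=O)N(C)c2cnc(Nc3ccc(C(=O)NC4CCN(C)CC4)cc3OC)nc2N1C(C)C` gives 4 nM in an assay on isolated protein for inhibition of serine/threonine-protein kinase PLK1 (Homo sapiens), read by Z'-LYTE; on this read-out higher numbers stand for weaker inhibition and lower numbers for stronger inhibition; compound 2 `COc1cc(C(=O)NC2CCN(C)CC2)ccc1Nc1ncc2c(n1)N(C1CCCC1)[C@H](CC(C)C)C(=O)N2C` gives 78 nM; compound 3 `COc1cc(C(=O)NC2CCN(C)CC2)ccc1Nc1ncc2c(n1)N(C(C)C)[C@H](C)C(=O)N2C` gives 25.2 nM.

In this assay compound 3 stands second highest of the three numbers, with compound 2 as its nearest neighbour and compound 1 as its furthest. Compound 4 `COc1cc(C(=O)NC2CCN(C)CC2)ccc1Nc1ncc2c(n1)N(C(C)C)[C@H](CC(C)C)C(=O)N2C` differs from compound 3 by isopropyl in place of hydrogen on a saturated chain carbon bound to a saturated ring carbon. Within the data shown here, the only measured step at this place is a 6.3-fold higher number from compound 1 to compound 3 (0.80 log units; beyond the scatter), where a shorter chain gave the higher number; the longer chain in compound 4 is therefore expected to lower the number, though compound 2, which carries the same isobutyl chain, gives 78 nM and cautions against a large step. Compound 4 is estimated at 15 nM, between 4 nM and 60 nM, an expected step of a 1.7-fold lower number from compound 3 to compound 4 (0.23 log units; within the scatter).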

Compound 4, half-maximal inhibitory concentration: 218 nM
Estimate against measurement, compound 4: 15-fold (1.16 log units) below; measured number above the stated range.
By their numbers in this assay, from the lowest: compound 1; then compound 3; then compound 2; then compound 4.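

At this saturated chain carbon the number does not simply fall as the chain lengthens: in this assay the isobutyl chain gives an 8.7-fold higher number from compound 3 to compound 4 (0.94 log units; beyond the scatter) and a 55-fold higher number from compound 1 to compound 4 (1.74 log units; beyond the scatter), so the ethyl chain of compound 1, not the longest chain, holds the lowest number. With the isobutyl chain held fixed, the group on the nitrogen also counts, as isopropyl in place of cyclopentyl gives a 2.8-fold higher number from compound 2 to compound 4 (0.45 log units; beyond the scatter). Nothing available explains these steps.

As far as these compounds go, it remains open whether a propyl chain or a chain ending in an amine at this carbon would fall nearer compound 1 or compound 4. From the compounds shown here alone, it also remains open whether cyclopentyl on that nitrogen would lower the number when paired with the ethyl chain.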